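Chain extension and lipophilicity across two cores

The source may report more compounds than this note shows. Statements on the series, on what has been measured and on what is new or still open speak of the compounds shown alone.

Measured so far in a physicochemical assay for lipophilicity; on this read-out lower numbers stand for lower lipophilicity and higher numbers for higher lipophilicity:
compound 1, `CCCCCOc1ccc2[nH]c(-c3ccc(OC)cc3)c(C3=C(Br)C(=O)NC3=O)c2c1`, gives 3.77
compound 2, `CCCCCCOc1ccc2[nH]c(-c3ccc(OC)cc3)c(C3=C(Br)C(=O)NC3=O)c2c1`, gives 4.1
compound 3, `CCCc1ccc2[nH]c(-c3ccccc3)c(C3=C(Br)C(=O)NC3=O)c2c1`, gives 3.43

From compound 1 to compound 2 the change is methyl in place of hydrogen on a saturated chain carbon, five bonds along the chain from an oxygen on an aromatic ring, and the step in this assay is a number 0.33 log units higher from compound 1 to compound 2 (beyond the scatter). Compound 4, `CCCCc1ccc2[nH]c(-c3ccccc3)c(C3=C(Br)C(=O)NC3=O)c2c1`, carries the analogous change on compound 3: methyl in place of hydrogen on a saturated chain carbon, three bonds along the chain from an aromatic carbon. The two places are not the same word for word, five bonds along the chain from an oxygen on an aromatic ring in the first pair against three bonds along the chain from an aromatic carbon in the second, so this is the same kind of change rather than the same change. The difference between the two cores is not broken down here; compound 3 simply stands lowest of the three measured values.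

For compound 4 in this assay a step of a number 0.33 log units higher from compound 3 to compound 4 (beyond the scatter) is expected, resting on the modest step of a number 0.33 log units higher from compound 1 to compound 2 (beyond the scatter) seen for the same kind of change. Compound 4 is therefore estimated at 3.76, with a range of 3.5 to 4.05.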

Compound 4, partition coefficient: 3.74
Compound 4: the middle estimate sits 0.02 log units above what was measured; the range from low to high includes it.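

In this assay the new step is a number 0.31 log units higher from compound 3 to compound 4 (beyond the scatter) and it runs in the same direction as a number 0.33 log units higher from compound 1 to compound 2 (beyond the scatter) so for these two pairs methyl in place of hydrogen on a saturated chain carbon carries from one core to the other. Going by these compounds alone, only two pairs support this, and the places differ, so it shows no rule for other chain lengths or other cores. Nothing available explains either step.

The compounds shown leave open whether the same step holds for a longer chain on either core. They also leave open how an amine or a carboxylic acid in place of the methyl would behave in this assay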